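Aryl sulfonyl variation in a weak alpha3/beta4 series

A few compounds are considered here, and "the series" means these few. Any claim that something is new, unique, unknown or untested is made for them only; others in the source may bear on it.

Measured compounds in an in vitro assay on HEK ts201 cells for negative allosteric modulation of Neuronal acetylcholine receptor; alpha3/beta4 (Homo sapiens), read by fluorescence and calcium flux, with a stated time of 1.5 s; on this read-out lower numbers stand for stronger inhibition and higher numbers for weaker inhibition:
compound 1 `O=C(CN1CCN(S(=O)(=O)c2ccc(F)cc2)CC1)Nc1ccc(F)cc1` gives 11600 nM
compound 2 `COc1ccc(S(=O)(=O)N2CCN(CC(=O)Nc3ccccc3F)CC2)cc1` gives 15400 nM
compound 3 `O=C(CN1CCN(S(=O)(=O)c2ccccc2F)CC1)Nc1ccc(F)cc1` gives 13600 nM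

All three numbers are weak and sit close together. Compound 3 stands second highest of the three, its nearest neighbour being compound 2 and its furthest compound 1, with both gaps within the scatter. Among the measured compounds shown here, the only single-point step among them, a 1.2-fold higher number from compound 1 to compound 3 (0.07 log units; within the scatter), shows that swapping the aryl group on the sulfonyl sulfur moved nothing beyond the scatter.

Compound 4 `COc1ccc(S(=O)(=O)N2CCN(CC(=O)Nc3ccc(F)cc3)CC2)cc1` is not yet measured. It differs from compound 3 by 4-methoxyphenyl in place of 2-fluorophenyl on a sulfonyl sulfur. This is again a change at the sulfonyl sulfur, the same place probed by the step from compound 1 to compound 3, which was flat. Compound 2 already carries 4-methoxyphenyl at this position with a number in the same weak band as compound 3. For compound 4 the expectation in this assay is therefore a step of a 1.0-fold lower number from compound 3 to compound 4 (0.00 log units; within the scatter), that is, none beyond the scatter. Compound 4 is estimated at 13500 nM, with a range from 7000 nM to 26000 nM.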

Compound 4, half-maximal inhibitory concentration: 17100 nM
Compound 4: the middle estimate sits 1.3-fold (0.10 log units) below what was measured; measured number inside the range.
By their numbers in this assay, from the lowest: compounds 1, 3, 2 and 4 (each within the scatter of the next).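

In this assay, 4-methoxyphenyl in place of 2-fluorophenyl on the sulfonyl sulfur gives a 1.3-fold higher number from compound 3 to compound 4 (0.10 log units; within the scatter) and extends the flat picture at this position beyond fluorophenyl isomers to a different substituent. Methoxy in place of fluoro on an aromatic carbon, with the rest of the molecule held constant, gives a 1.5-fold higher number from compound 1 to compound 4 (0.17 log units; within the scatter) as the narrowest reading of this exchange. Among the compounds shown here, the first step at the other end of the series, 4-fluorophenyl in place of 2-fluorophenyl on an amide-type nitrogen, gives a 1.1-fold higher number from compound 2 to compound 4 (0.05 log units; within the scatter) and shows no movement beyond the scatter at that place either.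

Open, on these data alone, is whether an amine or a carboxylic acid on the aryl group at the sulfonyl sulfur would shift the number beyond the scatter. Nothing available bears on why these steps are flat.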